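A few compounds are considered here, and "the series" means these few. Any claim that something is new, unique, unknown or untested is made for them only; others in the source may bear on it.

The measured compounds are:
compound 1, `O=c1[nH]cc(S(=O)(=O)Nc2ccc(-c3cn(-c4ccccc4F)nn3)cc2)c(=O)[nH]1`, which in an ADME assay on GES1 cells (Homo sapiens) for cytotoxicity, read by MTT assay, with a stated time of 24 h (a lower number here means that less compound is tolerated, a higher number that more compound is tolerated), gives > 100000 nM, a limit of the assay rather than a number;
compound 2, `O=c1[nH]cc(S(=O)(=O)Nc2ccc(-c3cn(-c4cccc(Cl)c4)nn3)cc2)c(=O)[nH]1`, which in this assay gives 7570 nM.

Compound 2 therefore holds the only number shown in this assay; the other value is a limit. Going by the values given here, the single measured step, an at least 13-fold lower number from compound 1 to compound 2 (1.12 log units; beyond the scatter), went with a 3-chlorophenyl in place of a 2-fluorophenyl on an aromatic nitrogen, with compound 1 sitting at the limit of > 100000 nM in this assay, at which 1 of the 2 values shown sits. Compound 3, `O=c1[nH]cc(S(=O)(=O)Nc2ccc(-c3cn(-c4ccc(Cl)cc4)nn3)cc2)c(=O)[nH]1`, differs from compound 2 by 4-chlorophenyl in place of 3-chlorophenyl on an aromatic nitrogen. Among the compounds with values here, no measured step compares a 3-chlorophenyl with a 4-chlorophenyl, so the one step recorded offers no direct guide here, and no change beyond the scatter is expected. Compound 3 is thus expected to lie near 7500 nM, within 2500 nM to 25000 nM, an estimated step of a 1.0-fold lower number from compound 2 to compound 3 (0.00 log units; within the scatter) in this assay.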

Compound 3, half-maximal cytotoxic concentration: 23300 nM
The estimate for compound 3 lay 3.1-fold (0.49 log units) below the measured number; measured number inside the range.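

In this assay, going by these compounds alone, the earlier compounds left it unclear whether the position of the chlorine on the phenyl group mattered, but 4-chlorophenyl in place of 3-chlorophenyl, with the same atoms joined differently, now gives a 3.1-fold higher number from compound 2 to compound 3 (0.49 log units; beyond the scatter). Both chlorophenyl compounds also read lower than the 2-fluorophenyl compound, and the new comparison gives an at least 4.2-fold lower number from compound 1 to compound 3 (0.63 log units; beyond the scatter). Compound 1 stands at a limit of the assay, so this step has no exact size: the limit of > 100000 nM in this assay, at which 1 of the 3 values shown sits.

Compound 1 differs from the other two in both the halogen and its position on the phenyl group, so the contribution of each remains unresolved. Going by these compounds, it also remains open how a methoxy group or an amine in place of the chlorine would read in this assay.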